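From a Furan Ring to an Open Chain

This account rests on a few compounds, and the source may have more. Where it says the series, first, only, none or still open, it means among the compounds named here.

Within the data shown here, compound 2 `Cc1ccc(-c2ccccc2NCC2=NCCN2)o1` holds the lowest of the two numbers measured so far: in a functional assay for activation of Alpha-1B adrenergic receptor (Homo sapiens), read by calcium flux (a lower number here means that less compound is needed, a higher number that more compound is needed for the effect), compound 2 gives 46.8 nM. Among the measured compounds shown here, its nearest neighbour, compound 1 `Cc1ccsc1-c1ccccc1NCC1=NCCN1`, gives 112 nM in this assay, and the single measured step, a 2.4-fold lower number from compound 1 to compound 2 (0.38 log units; beyond the scatter), swaps one five-membered aromatic ring for another. Compound 3 `CC/C(=N\OC)c1ccccc1NCC1=NCCN1` differs from compound 2 by a group of 6 heavy atoms (4 carbon, 1 nitrogen, 1 oxygen; no ring) in place of a group of 6 heavy atoms (5 carbon, 1 oxygen; one five-membered aromatic ring with 1 hetero atom), on an aromatic carbon. For the measured compounds named here, no measured step exchanges a ring for an open chain, so that step offers only weak guidance. Compound 3 is therefore expected to show a 3.2-fold higher number from compound 2 to compound 3 (0.51 log units; beyond the scatter), an estimate of 150 nM with a range from 40 nM to 600 nM.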

Compound 3, half-maximal effective concentration: < 100000 nM
Compound 3 ended at the assay's limit; the forecaster's own chance of this, stated with the estimate: 5%; the middle value is on the limit's open side.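

In this assay compound 3 gives < 100000 nM, which is a limit of the assay and not a number. Its steps from compound 1 and compound 2 therefore cannot be read. The compounds shown leave open how large the change is when an open chain replaces the five-membered aromatic ring.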